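Propanoyl to Butylcarbonyl on a Shared Core

The source may report more compounds than this note shows. Statements on the series, on what has been measured and on what is new or still open speak of the compounds shown alone.

Three measured compounds share one core and differ only on the aromatic ring. Compound 1 `CCC(=O)N1CCN(S(=O)(=O)c2ccccc2)CC1` gives in a functional assay on the whole organism with Mus musculus as the target (on this read-out higher numbers stand for an effect only at larger amounts of compound and lower numbers for an effect already at smaller amounts), a value of 0.1 mg/kg. Compound 2 `CCC(=O)N1CCN(S(=O)(=O)c2ccc(Cl)cc2)CC1` gives in this assay only a limit, > 0.1 mg/kg, and no number. Compound 3 `CCC(=O)N1CCN(S(=O)(=O)c2ccc(F)cc2)CC1` gives in this assay 0.01 mg/kg, the lowest of the two numbers shown; the gap to its nearest neighbour is a 10-fold lower number from compound 1 to compound 3 (1.00 log units; beyond the scatter), and an at least 10-fold lower number from compound 2 to compound 3 (1.00 log units; beyond the scatter) is no smaller. Compound 4 `CCCCC(=O)N1CCN(S(=O)(=O)c2ccc(F)cc2)CC1` differs from compound 3 by ethyl in place of hydrogen on a saturated chain carbon, two bonds along the chain from a carbonyl carbon. Going by the values given here, none of the measured steps touches this position: a number no lower from compound 1 to compound 2 (the limit leaves the size open) and a 10-fold lower number from compound 1 to compound 3 (1.00 log units; beyond the scatter) both concern the aromatic ring, so they give no guide to the acyl chain, and the expected step is none beyond the scatter, no change at the digits printed from compound 3 to compound 4 (within the scatter), with a wide range to reflect the missing precedent. Compound 4 is therefore estimated at 0.01 mg/kg in this assay, between 0.002 mg/kg and 0.05 mg/kg.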

Compound 4, minimum effective dose: > 0.1 mg/kg
Compound 4 gave a limit, no number; the forecaster's own chance of this, stated with the estimate: 15%; middle value at least 10-fold (1.00 log units) away from the limit.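

Going by these compounds alone, the acyl chain, which no earlier step had touched, proves to be a position that matters: with the fluoro group held in place, going from propanoyl to butylcarbonyl gives in this assay an at least 10-fold higher number from compound 3 to compound 4 (1.00 log units; beyond the scatter). The low value of compound 3 therefore does not survive this change, and the fluoro group alone does not secure it. Compound 4 gives only a limit, which leaves the real size of the step unread, and this same limit recurs in the set: the limit of > 0.1 mg/kg in this assay, at which 2 of the 4 values shown sit.

The compounds shown give this chain change only once, with the fluoro group present, and whether it would have the same outcome with hydrogen or chloro in that place stays open. Also open, on these data alone, is how an acetyl group, a branched chain, or a chain ending in an amine or a carboxylic acid would fare at this position.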